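Amide Variations on a Shared Core: What Compound 3 May Show

The source may hold more compounds than are shown below. What is called first, only, known or untested is meant among the compounds shown, and "the series" means these compounds.

Compound 1 `Cn1nnnc1NC(=O)c1cc(=O)c2ccccc2o1` gives 0% in a functional assay on the whole organism for inhibition, with Rattus norvegicus as the target, with a stated time of 30 min, at a dose of 1 mg/kg by the intravenous route; on this read-out higher numbers stand for more inhibition at the one dose given (going by the name of the read-out) and lower numbers for less inhibition.
Compound 2 `O=C(Nc1nc[nH]n1)c1cc(=O)c2ccccc2o1` gives 0% in this assay.

Compound 2 stands level with compound 1 on the numbers shown: the single measured step, no change at the digits printed from compound 1 to compound 2 (within the scatter), changed nothing beyond the scatter, so both amides sit at the bottom of the read-out with no separation between them.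

The unmeasured compound 3 `O=C(Nc1nccs1)c1cc(=O)c2ccccc2o1` differs from compound 2 in one place, (1,3-thiazol-2-yl in place of 1H-1,2,4-triazol-3-yl on an amide-type nitrogen). Going by the values given here, the only step that bears on this is the one from compound 1 to compound 2, which also exchanged one five-membered aromatic ring for another on the same amide-type nitrogen and left the read-out flat. On that evidence, the step from compound 2 to compound 3 is expected to stay within the scatter, with any movement more likely upward than downward simply because compound 2 gives 0% and cannot go lower; the expected step is a number 5 percentage points higher from compound 2 to compound 3 (within the scatter).

Compound 3 is therefore estimated at 5% in this assay, with a range from 0% to 25%.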

Compound 3, a percentage reported as inhibition, in the whole organism at one dose (the size of the read-out at that dose, not a potency): 15%
Compound 3: middle estimate off by 10 percentage points, on the low side; measured number inside the range.
By their numbers in this assay, from the lowest: compounds 1 and 2 (each within the scatter of the next); then compound 3.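

In this assay, the amide-type nitrogen proves able to move the read-out: putting 1,3-thiazol-2-yl in place of 1H-1,2,4-triazol-3-yl gives a number 15 percentage points higher from compound 2 to compound 3 (beyond the scatter) on this position, and putting it in place of 1-methyl-1H-tetrazol-5-yl gives a number 15 percentage points higher from compound 1 to compound 3 (beyond the scatter) on the same position. Going by these compounds alone, the earlier exchange of one five-membered aromatic ring for another, no change at the digits printed from compound 1 to compound 2 (within the scatter) as the only step then available, had suggested that the position might be insensitive, but the two new steps show that the identity of the ring matters here, although the size of the change remains modest. Between compound 2 and compound 3 the ring loses its hydrogen-bond donor and gains a sulfur atom in exchange for nitrogen, but these changes come together in one step and nothing available links either of them to the rise.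

From the compounds shown here alone, it remains open whether a six-membered ring such as pyridine on the amide-type nitrogen, or an amine or a carboxylic acid carried on the 1,3-thiazol-2-yl ring, would take the number further up or bring it back down. The compounds shown also leave open whether replacing the amide link itself, while keeping the 1,3-thiazol-2-yl ring, would preserve the step.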